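The compounds below may be only part of what the source reports. "The series", "measured", "known", "first", "only" and "open" are said of these compounds alone.

Compound 2 `CCCCc1cc2nn(-c3ccccc3)cc2cn1` gives 6700 nM in a functional assay on K562 cells (Homo sapiens) for inhibition, read by fluorescence, with a stated time of 72 h; a higher number here means a weaker inhibitor of growth, a lower number a stronger inhibitor of growth. Of the three measured compounds it stands second highest: compound 3 `Cc1nc(-c2ccccc2)cc2nn(-c3ccccc3)cc12`, which carries a phenyl rather than a chain and also a methyl, gives 6300 nM, within the scatter of compound 2, while compound 1 `CCCCc1cc2nn(-c3ccccc3)cc2c(C(C)C)n1` gives 12900 nM. Within the data shown here, the only single-point step measured so far is a 1.9-fold lower number from compound 1 to compound 2 (0.28 log units; within the scatter). Compound 4 `c1ccc(-n2cc3cnc(-c4ccsc4)cc3n2)cc1` is made from compound 2 by thiophen-3-yl in place of butyl on an aromatic carbon. Among the measured compounds shown here, no measured step exchanges a chain for an aromatic ring, and the step from compound 1 to compound 2 bears only loosely on it; the numbers for compound 2 and compound 3 sit within the scatter of each other. No step beyond the scatter is therefore expected in this assay . Compound 4 is estimated at 5000 nM, range 1500 nM to 15000 nM, an expected step of a 1.3-fold lower number from compound 2 to compound 4 (0.13 log units; within the scatter).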

Compound 4, concentration for 50% growth inhibition: 8300 nM
Compound 4: the middle estimate sits 1.7-fold (0.22 log units) below what was measured; low and high end bracket the measured number.
By their numbers in this assay, from the lowest: compounds 3, 2, 4 and 1 (each within the scatter of the next, the first and the last beyond it).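

At this position, on the aromatic carbon next to the ring nitrogen, thiophen-3-yl in place of butyl gives a 1.2-fold higher number from compound 2 to compound 4 (0.09 log units; within the scatter) in this assay. This direct exchange of an open chain for a five-membered aromatic ring therefore does not separate the two groups in this assay. Nothing measured bears on why they read alike. From the compounds shown here alone, what an amine, a carboxylic acid or a longer chain would do at this carbon stays open. Also open, going by these compounds, is whether thiophen-3-yl would read the same alongside the isopropyl of compound 1.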